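The compounds below may be only part of what the source reports. "The series", "measured", "known", "first", "only" and "open" are said of these compounds alone.

Measured so far:

Compound 1, `C[C@H](Nc1nc(N)nc(N)c1C#N)c1cc2ccc(F)cn2c(=O)c1-c1ccccc1`, gives 1.3 L/kg in an ADME assay on the whole organism (Mus musculus, strain BALB/C) for pharmacokinetics, read by LC-MS, with a stated time of 24 h, at a dose of 1 mg/kg by the intravenous route; on this read-out higher numbers stand for wider distribution into tissues and lower numbers for narrower distribution.
Compound 2, `C[C@H](Nc1nc(N)nc(N)c1C#N)c1cc(=O)n2cc(F)ccc2c1-c1cc(F)cc(F)c1`, gives 1.9 L/kg in this assay.

These two numbers sit close together, and their gap falls within the usual scatter of this assay, so they read as alike, with compound 1 at the low end of the pair. Compound 3, `Cc1c([C@H](C)Nc2nc(N)nc(N)c2C#N)c(-c2ccccc2)c(=O)n2cc(F)ccc12`, has not yet been measured in this assay. Compared with compound 1 it carries one change: methyl in place of hydrogen on an aromatic carbon. Among the measured compounds shown here, no pair among the measured compounds shows what such a change does here, so nothing in the data points to a step in either direction. The expectation for the step from compound 1 to compound 3 is therefore one that stays within the scatter, a 1.2-fold higher number from compound 1 to compound 3 (0.06 log units; within the scatter). On that basis compound 3 is estimated at 1.5 L/kg, with a range from 0.9 L/kg to 2.6 L/kg.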

Compound 3, volume of distribution at steady state: 1.7 L/kg
Compound 3: the middle estimate sits 1.1-fold (0.05 log units) below what was measured; the measured number falls inside the stated range.
By their numbers in this assay, from the lowest: compounds 1, 3 and 2 (each within the scatter of the next).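

Methyl in place of hydrogen on this aromatic carbon gives a 1.3-fold higher number from compound 1 to compound 3 (0.12 log units; within the scatter) in this assay, so this single added carbon does not produce a readable difference. Among the compounds shown here, this is the first sign of how this position behaves: on a six-membered aromatic ring with 1 nitrogen, two atoms from the ring nitrogen, it can carry methyl with the read-out staying within the usual spread of repeat measurements. Nothing measured here gives a reason for this result.

This is a single pair and a single group, so it cannot show a general rule for the position. An amine, a carboxylic acid or a longer chain on the same carbon could behave differently, and the compounds shown leave that question open.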